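Fluorobenzyl ether on a cytotoxicity scaffold at its limit

The compounds below may be only part of what the source reports. "The series", "measured", "known", "first", "only" and "open" are said of these compounds alone.

Compound 1, `COc1cc(OC)c2c(c1)C(C(O)c1ccc(O)cc1)OC2=O`, in an ADME assay on RAW264.7 cells (Mus musculus) for cytotoxicity, read by MTT assay, with a stated time of 24 h, in the presence of a further agent that is not named here (a lower number here means a stronger inhibitor, a higher number a weaker inhibitor), gives > 40000 nM, which is a limit of the assay rather than a number.
Compound 2, `CCCCCCOc1ccc(C(O)C2OC(=O)c3c(OC)cc(OC)cc32)cc1`, in this assay gives > 40000 nM, again a limit.

Compound 2 therefore stands only at the limit. Compound 3, `COc1cc(OC)c2c(c1)C(C(O)c1ccc(OCc3ccc(F)cc3)cc1)OC2=O`, differs from compound 2 by 4-fluorophenyl in place of pentyl on a saturated chain carbon bound to an oxygen on an aromatic ring. Going by the values given here, the one measured step, a step that the two limits leave unreadable from compound 1 to compound 2, cannot be read because the limit of > 40000 nM in this assay, at which 2 of the 2 values shown sit, shows both values at the limit. No readable step guides the expectation, and the expected step that the limit leaves unreadable from compound 2 to compound 3 is none beyond the scatter. Compound 3 is estimated at 60000 nM, between 20000 nM and 200000 nM, most likely reported as a limit again.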

Compound 3, half-maximal inhibitory concentration: > 40000 nM
Compound 3 was reported as a limit; the forecaster's own chance of this, stated with the estimate: 85%; the middle value lies beyond the limit too.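

The steps among compound 1, compound 2 and compound 3 cannot be read, because all three results are limits rather than numbers: the limit of > 40000 nM in this assay, at which 3 of the 3 values shown sit.
Going by these compounds, what stays open is the true value of each compound in this assay and whether the hexyl or 4-fluorobenzyl group changes it at all.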